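The compounds below may be only part of what the source reports. "The series", "measured", "known", "first", "only" and "open" are said of these compounds alone.

Of the compounds shown here, three share one core and have been measured in an assay on SK-BR-3 cells for inhibition of Aromatase (Homo sapiens); a higher number here means a weaker inhibitor, a lower number a stronger inhibitor. Compound 1 `CN(c1ccc([N+](=O)[O-])cc1OCc1ccc(Cl)cc1)S(C)(=O)=O` gives 2400 nM. Compound 2 `CN(c1ccc(N)cc1OCc1ccccc1)S(C)(=O)=O` gives 1100 nM. Compound 3 `CN(c1ccc(NC(=O)c2ccccc2)cc1OCc1ccccc1)S(C)(=O)=O` gives 1770 nM, a number that lies within the usual scatter of both compound 1 and compound 2, so the three cannot be told apart. Among the measured compounds shown here, the one step between neighbours, a 1.6-fold higher number from compound 2 to compound 3 (0.21 log units; within the scatter), is itself small. Compound 4 `CN(c1ccc(NC(=O)c2ccc(Cl)c([N+](=O)[O-])c2)cc1OCc1ccccc1)S(C)(=O)=O` is not yet measured; it differs from compound 3 only in 4-chloro-3-nitrophenyl in place of phenyl on a carbonyl carbon. For the measured compounds named here, no measured step changes the group on that carbonyl carbon, so nothing here predicts a shift in this assay. Compound 4 is therefore expected to give 1700 nM, between 700 nM and 4500 nM, a change estimated as a 1.0-fold lower number from compound 3 to compound 4 (0.02 log units; within the scatter).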

Compound 4, half-maximal inhibitory concentration: 690 nM
Estimate against measurement, compound 4: 2.5-fold (0.39 log units) above; measured number outside the range, below it.
By their numbers in this assay, from the lowest: compounds 4, 2, 3 and 1 (each within the scatter of the next, the first and the last beyond it).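

In this assay, among the compounds shown here, the group on the carbonyl carbon proves able to shift the number: 4-chloro-3-nitrophenyl in place of phenyl gives a 2.6-fold lower number from compound 3 to compound 4 (0.41 log units; beyond the scatter), the only step here beyond the scatter. The earlier step, which added the benzoyl group to the nitrogen, stayed within it. Nothing available gives a reason for this shift.

The chlorine and the nitro group enter together, and the compounds shown cannot separate their contributions. On these data alone, how 4-chlorophenyl alone, 3-nitrophenyl alone, or an amine in place of the nitro group would read remains open.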